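Reversing a nitrile-for-chlorine swap on a flavonol ether

The compounds below may be only part of what the source reports. "The series", "measured", "known", "first", "only" and "open" are said of these compounds alone.

Going by the values given here, in an ADME assay on Huh-5-2 cells (Homo sapiens) for cytotoxicity, read by WST assay, with a stated time of 3 days (on this read-out higher numbers stand for lower toxicity in this test and lower numbers for higher toxicity in this test), compound 3 `N#Cc1cccc(COc2cc(O)c3c(=O)c(O)c(-c4ccccc4)oc3c2)c1` gives 72000 nM, the only actual number among the three measured compounds. Compound 1 `O=c1c(O)c(-c2ccccc2)oc2cc(OCc3cccc(Cl)c3)cc(O)c12` reaches only the limit of the test, > 100000 nM. Compound 2 `O=c1c(O)c(-c2ccccc2)oc2cc(OCc3cccc(Br)c3)cc(O)c12` likewise stops at the limit, > 100000 nM. Both of these sit at the limit of > 100000 nM in this assay, at which 2 of the 3 values shown sit, so the step that the two limits leave unreadable from compound 1 to compound 2 cannot be read.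

Compound 4 `O=c1c(O)c(-c2ccccc2)oc2cc(OCc3ccc(Cl)cc3)cc(O)c12` differs from compound 3 by 4-chlorophenyl in place of 3-cyanophenyl on a saturated chain carbon bound to an oxygen on an aromatic ring. The measured steps that come closest are an at least 1.3-fold lower number from compound 1 to compound 3 (0.14 log units; that floor lies within the scatter) and an at least 1.3-fold lower number from compound 2 to compound 3 (0.14 log units; that floor lies within the scatter), each replacing a halogen with a nitrile; both point toward a lower number, though only by a floor that lies within the ordinary scatter. Compound 4 runs that exchange backwards, returning to a chlorine, while the cyano group departs entirely.

A modest rise is therefore expected, back toward the limit, and the step of a 1.4-fold higher number from compound 3 to compound 4 (0.14 log units; within the scatter) is estimated since the measured step of an at least 1.3-fold lower number from compound 1 to compound 3 (0.14 log units; that floor lies within the scatter) ran the other way by at least a similar amount. Compound 4 is expected to give about 100000 nM, within a range from 50000 nM to 200000 nM.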

Compound 4, half-maximal cytotoxic concentration: > 100000 nM
Compound 4 was reported as a limit; the forecaster's own chance of this, stated with the estimate: 55%; the middle value lies on the limit itself.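

Compound 4 is reported only as a limit, so a chlorine on the 4-chlorophenyl group leaves the read-out as unresolved as the chlorine on the 3-chlorophenyl group of compound 1 did. In this assay, exchanging 3-cyanophenyl for 4-chlorophenyl on a saturated chain carbon bound to an oxygen on an aromatic ring gives an at least 1.3-fold higher number from compound 3 to compound 4 (0.14 log units; that floor lies within the scatter), so this further change of group still does not set compound 3 clearly apart. The steps from compound 1 and compound 2 to compound 4 cannot be read, and the compounds now crowd together at the top of the test: the limit of > 100000 nM in this assay, at which 3 of the 4 values shown sit.

The compounds shown leave open whether any change at this position can bring the number clearly down, for instance an amine or a carboxylic acid on the ring, or a longer chain in place of the benzyl group. They also leave open how much of the step comes from the nitrile itself and how much from where it sits, a question that 4-cyanophenyl would address.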